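Adding a Second Methoxy to the Core of Compound 1

The source may report more compounds than this note shows. Statements on the series, on what has been measured and on what is new or still open speak of the compounds shown alone.

Compound 1 `COc1ccc(C(=O)c2cc(OC)c(OC)c(OC)c2)cc1NC(=O)/C=C/c1ccc(C(F)(F)F)cc1` was tested in a functional assay on ME-180 cells (Homo sapiens) for cytotoxicity, read by MTT assay, with a stated time of 72 h (a lower number here means a stronger inhibitor, a higher number a weaker inhibitor), where compound 1 gives 800 nM, the lowest of the two numbers seen. Compound 2 `COc1ccc(C(=O)c2cc(OC)c(OC)c(OC)c2)cc1NC(=O)/C=C/c1ccc(F)c(F)c1` differs from compound 1 in one place, and in this assay compound 2 gives 8900 nM; the step of an 11-fold higher number from compound 1 to compound 2 (1.05 log units; beyond the scatter) is large. Compound 3 `COc1cc(C(=O)c2cc(OC)c(OC)c(OC)c2)cc(NC(=O)/C=C/c2ccc(C(F)(F)F)cc2)c1OC` instead carries methoxy in place of hydrogen on an aromatic carbon. For the measured compounds named here, no measured step touches this position, so the one known step does not bear on it. Compound 3 is therefore expected to show a 1.3-fold higher number from compound 1 to compound 3 (0.10 log units; within the scatter), nothing beyond the scatter. The estimate for compound 3 is 1000 nM, ranging from 300 nM to 4000 nM.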

Compound 3, half-maximal inhibitory concentration: 3600 nM
Beside the measured number, compound 3's estimate is 3.6-fold (0.56 log units) below it; the range from low to high includes it.
By their numbers in this assay, from the lowest: compound 1; then compound 3; then compound 2.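

In this assay, this aromatic carbon proves sensitive to substitution: methoxy in place of hydrogen gives a 4.5-fold higher number from compound 1 to compound 3 (0.65 log units; beyond the scatter) and so weakens the compound, although the entering group holds only 2 heavy atoms. For the compounds shown here, the earlier step concerned the other end of the molecule, so this is the first sign that this position on the core matters. Nothing available here explains the loss. Going by these compounds, whether a hydroxyl or an amine on this carbon would also weaken the compound remains open. So does whether methoxy would have the same effect alongside the 3,4-difluorophenyl of compound 2.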